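The source may hold more compounds than are shown below. What is called first, only, known or untested is meant among the compounds shown, and "the series" means these compounds.

Measured so far in a physicochemical assay for solubility, in phosphate buffer, at pH 7.4 (on this read-out lower numbers stand for lower solubility and higher numbers for higher solubility), are three compounds:
compound 1 `CC(C)n1cc(-c2ccnc3[nH]c(C4CCNCC4)cc23)ccc1=O` gives 910000 nM 
compound 2 `CC(=O)N1CCC(c2cc3c(-c4ccc(=O)n(C(C)C)c4)ccnc3[nH]2)CC1` gives 27000 nM 
compound 3 `COc1cc(F)ccc1-c1ccnc2[nH]c(C3CCN(CC(=O)N(C)C)CC3)cc12` gives 38000 nM 

Compound 3 cannot be told apart from compound 2 within the usual scatter of repeated measurements, and both stand well under compound 1 on these numbers.

Compound 4 `COc1cc(=O)n(C)cc1-c1ccnc2[nH]c(C3CCN(CC(=O)N(C)C)CC3)cc12` has not yet been measured. Within the data shown here, its only change from compound 3 is a group of 10 heavy atoms (7 carbon, 1 nitrogen, 2 oxygen; one six-membered aromatic ring with 1 hetero atom) in place of a group of 9 heavy atoms (7 carbon, 1 oxygen, 1 fluorine; one six-membered aromatic ring of carbon only), on an aromatic carbon, and the group that leaves is 4-fluoro-2-methoxyphenyl.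

Among the measured compounds shown here, no measured step makes this exchange. For the measured compounds named here, the only measured step, a 34-fold lower number from compound 1 to compound 2 (1.53 log units; beyond the scatter), is large, but it is acetyl in place of hydrogen on an amine nitrogen in a ring, elsewhere in the molecule, so it is no direct guide. The nearest hint is compound 2, which carries a six-membered aromatic ring with 1 hetero atom at that place. Compound 2 at 27000 nM lies within the scatter of compound 3, although the two also differ elsewhere.

A modest upward step is therefore expected, a 2.6-fold higher number from compound 3 to compound 4 (0.42 log units; beyond the scatter) in this assay, far short of the large measured one, though the direction is not firmly settled. Compound 4 is expected at 100000 nM with a range from 35000 nM to 400000 nM in this estimate.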

Compound 4, solubility: 670000 nM
Estimate against measurement, compound 4: 6.7-fold (0.83 log units) below; the whole stated range lies below it.
By their numbers in this assay, from the lowest: compounds 2 and 3 (each within the scatter of the next); then compounds 4 and 1 (each within the scatter of the next).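

In this assay, putting the new group, with its six-membered aromatic ring with 1 hetero atom, in place of 4-fluoro-2-methoxyphenyl on the aromatic carbon opposite the ring nitrogen gives an 18-fold higher number from compound 3 to compound 4 (1.25 log units; beyond the scatter). Among these compounds, this shows that an exchange at this position alone, with the rest of the molecule unchanged, can produce a large step, whereas the only earlier step, a 34-fold lower number from compound 1 to compound 2 (1.53 log units; beyond the scatter), came from a change at the amine nitrogen in a ring elsewhere in the molecule and ran in the opposite direction. No measurement shown here explains why the number rises with this exchange.

The two groups differ in several ways at once, so these compounds cannot show which part of the exchange carries the step, and a plain phenyl ring or a 2-methoxyphenyl group without the fluorine at the same position would be needed to begin separating them. Going by these compounds, it also remains open whether the same exchange would give a step of similar size with the hydrogen or the acetyl on the ring nitrogen, as in compound 1 and compound 2, instead of the chain carried by compound 3 and compound 4.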